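The source may report more compounds than this note shows. Statements on the series, on what has been measured and on what is new or still open speak of the compounds shown alone.

Measured so far in an ADME assay on a cell-free system (plasma, Rattus norvegicus) for metabolic stability, read by LC-MS, with a stated time of 60 min, at 37 degrees C, tested at 50 uM; on this read-out lower numbers stand for a less stable compound and higher numbers for a more stable compound:
Compound 1 `Cc1oc(=O)oc1COC(=O)N1C[C@@H]2C[C@H]1C(=O)Nc1cccc(c1)C(=O)OCc1oc(=O)oc1COC(=O)C1=C(S2)[C@H](C)[C@@H]2[C@@H]([C@@H](C)O)C(=O)N12` gives 0% in this assay.
Compound 2 `C[C@@H](O)[C@H]1C(=O)N2C3=C(S[C@@H]4CN[C@@H](C4)C(=O)Nc4cccc(c4)C(=O)OC/C=C\COC3=O)[C@H](C)[C@H]12` gives 0% in this assay.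
Compound 3 `Cc1oc(=O)oc1COC(=O)N1C[C@@H]2C[C@H]1C(=O)Nc1cccc(c1)C(=O)OC/C=C\COC(=O)C1=C(S2)[C@H](C)[C@@H]2[C@@H]([C@@H](C)O)C(=O)N12` gives 0% in this assay.

Compound 4 `C[C@@H](O)[C@H]1C(=O)N2C3=C(S[C@@H]4CN[C@@H](C4)C(=O)Nc4cccc(c4)C(=O)OCc4oc(=O)oc4COC3=O)[C@H](C)[C@H]12` is not yet measured.

Compound 3 and compound 2 differ by a hydrogen atom in place of a group of 11 heavy atoms (6 carbon, 5 oxygen; one five-membered aromatic ring with 2 hetero atoms), on an amine nitrogen in a ring, and the step of no change at the digits printed from compound 3 to compound 2 (within the scatter). Compound 1 and compound 4 differ by a hydrogen atom in place of a group of 11 heavy atoms (6 carbon, 5 oxygen; one five-membered aromatic ring with 2 hetero atoms), on an amine nitrogen in a ring. This is the same kind of change, not the same: around the place, the five-membered non-aromatic ring with 1 nitrogen is part of a fused or bridged system of six rings in compound 1, of five rings in compound 3. How the cores of compound 1 and compound 3 differ is not broken down here; compound 1 stands level with compounds 2 and 3 within the scatter.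

The step from compound 1 to compound 4 is expected to be no change at the digits printed from compound 1 to compound 4 (within the scatter) in this assay, because no change at the digits printed from compound 3 to compound 2 (within the scatter) showed no movement and compound 1 already gives 0%. Compound 4 is therefore estimated at 0%, expected between 0% and 5%.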

Compound 4, percent of the compound remaining in the plasma assay: 0%
For compound 4 middle estimate and measured number coincide at the digits printed; the measured number falls inside the stated range.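

In the plasma assay a hydrogen atom in place of the group of 11 heavy atoms on the amine nitrogen in a ring gives no change at the digits printed from compound 1 to compound 4 (within the scatter), and the change reads alike on both cores: the same change on two cores in the plasma assay, no change at the digits printed (within the scatter) from compound 3 to compound 2 and no change at the digits printed (within the scatter) from compound 1 to compound 4, 0 percentage points apart, within the scatter of two such steps. This shows agreement only at the bottom of the read-out, where both steps start and end, and it does not show that the change would carry over between cores where a movement could be seen. The step between the same two compounds in a physicochemical assay for metabolic stability, read by LC-MS, in phosphate buffer, with a stated time of 3 h, at pH 7.4, tested at 50 uM (on this read-out lower numbers stand for a less stable compound and higher numbers for a more stable compound), cannot be read, as both values are limits of the assay: the limit of > 95% in the physicochemical assay, at which 2 of the 2 values shown sit. In the physicochemical assay compound 1 gives > 95% as a limit of the assay. In the physicochemical assay compound 4 gives > 95% as a limit of the assay.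

Open, from the compounds shown here alone, is how an acetyl group on the same amine nitrogen would read in the plasma assay. Also open, going by these compounds, is whether any compound with a longer chain in that place would leave the bottom of the read-out.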